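The source may hold more compounds than are shown below. What is called first, only, known or untested is meant among the compounds shown, and "the series" means these compounds.

In a functional assay on K562 cells (Homo sapiens) for antiproliferative activity, read by MTT assay, with a stated time of 48 h (a higher number here means a weaker inhibitor, a lower number a stronger inhibitor), compound 1 `Cn1cc(C2=C(c3nn(CCCN4CCCCC4)c4ncccc34)C(=O)N(c3ccccc3)C2=O)c2ccccc21` gives 3790 nM. Compound 3 `Cn1cc(C2=C(c3nn(CCCN4CCCCC4)c4ncccc34)C(=O)N(c3ccccn3)C2=O)c2ccccc21` reports only > 100000 nM, which is a limit and not a number; this is the limit of > 100000 nM in this assay, at which 1 of the 3 values shown sits. Compound 4 `Cn1cc(C2=C(c3nn(CCCN4CCCCC4)c4ncccc34)C(=O)NC2=O)c2ccccc21` carries hydrogen in place of pyridin-2-yl on an amide-type nitrogen in a ring. Among the measured compounds shown here, one measured step bears on this place: an at least 26-fold higher number from compound 1 to compound 3 (1.42 log units; beyond the scatter), with pyridin-2-yl in place of phenyl. Compound 2 `Cn1cc(C2=C(c3nn(CCCn4cccc4)c4ncccc34)C(=O)NC2=O)c2ccccc21` has hydrogen at this place with a different chain and gives 21600 nM. Removing pyridin-2-yl is therefore expected to give a large step to a lower number in this assay. The expected step is an at least 12-fold lower number from compound 3 to compound 4 (1.09 log units; beyond the scatter). For compound 4 the estimate is 8000 nM, with an expected range of 1500 nM to 40000 nM.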

Compound 4, half-maximal inhibitory concentration: 5960 nM
Compound 4: middle estimate off by 1.3-fold (0.13 log units), on the high side, and the stated range covers the measured number.
By their numbers in this assay, from the lowest: compounds 1 and 4 (each within the scatter of the next); then compound 2. At a limit, above all of these: compound 3.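

On the amide-type nitrogen in a ring, pyridin-2-yl stands apart in this assay: hydrogen in its place gives an at least 16-fold lower number from compound 3 to compound 4 (1.22 log units; beyond the scatter), whereas hydrogen in place of phenyl gives a 1.6-fold higher number from compound 1 to compound 4 (0.20 log units; within the scatter). With hydrogen on that nitrogen, the chain also counts: piperidin-1-yl in place of 1H-pyrrol-1-yl gives a 3.6-fold lower number from compound 2 to compound 4 (0.56 log units; beyond the scatter). Compound 3 has only a limit, so its step is a minimum: the limit of > 100000 nM in this assay, at which 1 of the 4 values shown sits.

As far as these compounds go, whether other groups on that nitrogen, such as methyl or benzyl, would track phenyl or pyridin-2-yl remains open. So does the effect of a dimethylamino group or morpholin-4-yl at the chain end.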